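Chloro in place of hydrogen on the fused system of compound 2

The source may report more compounds than this note shows. Statements on the series, on what has been measured and on what is new or still open speak of the compounds shown alone.

In a functional assay on lung (Cavia porcellus) for binding affinity to cysteinyl leukotriene receptor (Homo sapiens) (a higher number here means a weaker inhibitor, a lower number a stronger inhibitor), compound 2 `O=C(O)CCCOc1cccc(/C=C/c2ccc3ccccc3n2)c1` gives 480 nM, the lowest of the three numbers recorded. Compound 3 `Oc1cccc(/C=C/c2ccc3ccccc3n2)c1` gives 560 nM in this assay; the step of a 1.2-fold higher number from compound 2 to compound 3 (0.07 log units; within the scatter) keeps the two within the scatter, so no order between them can be read. Compound 1 `COC(=O)COc1cccc(/C=C/c2ccc3ccccc3n2)c1` gives 1000 nM in this assay, and the step of a 2.1-fold lower number from compound 1 to compound 2 (0.32 log units; beyond the scatter) lies beyond the scatter, while a 1.8-fold lower number from compound 1 to compound 3 (0.25 log units; within the scatter) does not. Compound 4 `O=C(O)CCCOc1cccc(/C=C/c2ccc3c(Cl)cccc3n2)c1` differs from compound 2 by chloro in place of hydrogen on an aromatic carbon. Among the measured compounds shown here, all three measured steps alter the group on the oxygen on the aromatic ring; none touches the fused two-ring system where the chloro enters, so no measured step bears directly on this change. The measured steps were modest at most, and nothing in them points to a direction. For compound 4 the expected step in this assay is a 1.2-fold lower number from compound 2 to compound 4 (0.08 log units; within the scatter), which is not expected to reach beyond the scatter. The estimate for compound 4 is 400 nM in this assay, with a range from 150 nM to 1100 nM.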

Compound 4, half-maximal inhibitory concentration: 1430 nM
Beside the measured number, compound 4's estimate is 3.6-fold (0.55 log units) below it; the measured number lies above the stated range.
By their numbers in this assay, from the lowest: compounds 2, 3, 1 and 4 (each within the scatter of the next, the first and the last beyond it).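

In this assay, chloro in place of hydrogen gives a 3.0-fold higher number from compound 2 to compound 4 (0.47 log units; beyond the scatter), a modest step but one beyond the scatter. This is the first change shown on the fused system rather than on the group on the oxygen, and it shows that this carbon, ortho to a fused ring and meta to a fused ring, does not tolerate chloro without cost: the number rises, marking a weaker inhibitor. The data offer no explanation for this rise.

Going by these compounds, whether the step is specific to chloro remains open, as a fluoro or a methyl group on the same carbon would be needed to tell. On these data alone, it is also open whether chloro on the other carbons of the fused system, or with a shorter carboxylic acid chain on the oxygen, would give a step of the same direction.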